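This account rests on a few compounds, and the source may have more. Where it says the series, first, only, none or still open, it means among the compounds named here.

Measured compounds:
Compound 1 `COc1cc(/C=C/C(=O)c2ccc(OCCn3cc(CN4C(=O)/C=C/C(C)(C)C/C=C(\C)CC/C=C/4C)nn3)cc2O)cc(OC)c1OC` gives 2.78 ug/mL in a functional assay on MCF7 cells (Homo sapiens) for antiproliferative activity; a higher number here means a weaker inhibitor, a lower number a stronger inhibitor.
Compound 2 `C/C1=C\CC(C)(C)/C=C/C(=O)N(Cc2cn(CCOc3ccc(C(=O)/C=C/c4ccc(C)cc4)c(O)c3)nn2)/C(C)=C/CC1` gives 1.21 ug/mL in this assay.
Compound 3 `COc1cc(/C=C/C(=O)c2ccc(OCCCN3C(=O)/C=C/C(C)(C)C/C=C(\C)CC/C=C/3C)cc2)cc(OC)c1OC` gives 0.58 ug/mL in this assay.

Compound 3 gives the lowest number of the three in this assay; the two others stand beyond the scatter above it. Compound 1 and compound 2 differ in one place, (4-methylphenyl in place of 3,4,5-trimethoxyphenyl on a double-bonded chain carbon bound to a double-bonded chain carbon), and this change gave a 2.3-fold lower number from compound 1 to compound 2 (0.36 log units; beyond the scatter). The cores of compound 1 and compound 3 differ in more than one place; that difference is not broken down here.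

Compound 4 `C/C1=C\CC(C)(C)/C=C/C(=O)N(CCCOc2ccc(C(=O)/C=C/c3ccc(C)cc3)cc2)/C(C)=C/CC1` is not yet measured in this assay. It stands to compound 3 as compound 2 stands to compound 1: the change is 4-methylphenyl in place of 3,4,5-trimethoxyphenyl on a double-bonded chain carbon bound to a double-bonded chain carbon, the same change as before. Were the step to carry over to the core of compound 3, compound 4 would be expected to move by about a 1.9-fold lower number from compound 3 to compound 4 (0.29 log units; within the scatter) in this assay, resting on the step seen from compound 1 to compound 2, a 2.3-fold lower number from compound 1 to compound 2 (0.36 log units; beyond the scatter). Among the measured compounds shown here, since only one prior example exists and the cores differ, the expectation is held with a wide range. Compound 4 is expected to give about 0.3 ug/mL in this assay, between 0.12 ug/mL and 0.75 ug/mL.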

Compound 4, half-maximal inhibitory concentration: 1.21 ug/mL
The estimate for compound 4 lay 4.0-fold (0.61 log units) below the measured number, outside the stated range (above it).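

In this assay, 4-methylphenyl in place of 3,4,5-trimethoxyphenyl gives a 2.1-fold higher number from compound 3 to compound 4 (0.32 log units; beyond the scatter) and so runs opposite to the earlier step on the core of compound 1, a gap that is larger than scatter alone would explain: the same change on two cores in this assay, a 2.3-fold lower number (0.36 log units; beyond the scatter) from compound 1 to compound 2 and a 2.1-fold higher number (0.32 log units; beyond the scatter) from compound 3 to compound 4, 4.8-fold (0.68 log units) apart, beyond the scatter of two such steps

The size and direction of this change therefore do not carry from one of these cores to the other, and a step read on one core gives no safe estimate for the other. This does not show which feature of the cores reverses the step, since they differ in more than one place, and with a single pair on each core it gives no general rule for either.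

Still open, from the compounds shown here alone, is which of the differences between the core of compound 1 and the core of compound 3 sets the direction of the step. Also open, going by these compounds, is how a phenyl group carrying an amine or a carboxylic acid, placed on the same double-bonded chain carbon, would behave on each core.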